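Dichlorophenylpiperazine naphthamides: dopamine transporter binding notes

The source may hold more compounds than are shown below. What is called first, only, known or untested is meant among the compounds shown, and "the series" means these compounds.

Compound 2 `O=C(NCCCN1CCN(c2ccccn2)CC1)c1ccc2ccccc2c1` has been tested in an assay on HEK293 cells for inhibition of sodium-dependent dopamine transporter (Homo sapiens), read by scintillation counting (on this read-out higher numbers stand for weaker inhibition and lower numbers for stronger inhibition), and gives only a limit, > 10000 nM. Compound 1 `O=C(NCCCN1CCN(c2cccc(Cl)c2Cl)CC1)c1cccc2ccccc12` likewise gives only a limit in this assay, > 10000 nM. Both values sit at the limit of > 10000 nM in this assay, at which 2 of the 2 values shown sit, so compound 2 cannot be ranked against compound 1; the two values show only that both lie at the limit. Among the measured compounds shown here, no step between measured compounds can be computed from this pair.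

Compound 3 `O=C(NCCCN1CCN(c2cccc(Cl)c2Cl)CC1)c1ccc2ccccc2c1` has not yet been measured in this assay. It differs from compound 2 by 2,3-dichlorophenyl in place of pyridin-2-yl on an amine nitrogen in a ring. Compound 1 carries the same 2,3-dichlorophenyl group on the ring nitrogen and, as noted, reaches only a limit in this assay. Every value shown so far is a limit, and no direction or size of step is supported by the data. The expected step, a step that the limit leaves unreadable from compound 2 to compound 3, is none beyond the scatter, with a further limit the most probable outcome. Compound 3 is estimated at 15000 nM, within a range of 4000 nM to 60000 nM.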

Compound 3, half-maximal inhibitory concentration: > 10000 nM
Compound 3 was reported as a limit; the forecaster's own chance of this, stated with the estimate: 75%; the middle value is on the limit's open side.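

Compound 3 gives only a limit in this assay, > 10000 nM. No step to compound 3 from compound 1 or compound 2 can be read, as all three compounds sit at the same limit: the limit of > 10000 nM in this assay, at which 3 of the 3 values shown sit.

The compounds shown leave open whether 2,3-dichlorophenyl in place of pyridin-2-yl, or naphthalen-2-yl in place of naphthalen-1-yl, changes inhibition at all.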